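This account rests on a few compounds, and the source may have more. Where it says the series, first, only, none or still open, it means among the compounds named here.

Of the compounds shown here, three built on a shared core have been measured in a physicochemical assay for lipophilicity, at pH 7.4; on this read-out lower numbers stand for lower lipophilicity and higher numbers for higher lipophilicity. Compound 1 `CCc1nc2nc(C)cc(Nc3cccc(Cl)c3)n2n1` gives 2.8. Compound 2 `Cc1cc(Nc2ccc(S(F)(F)(F)(F)F)cc2)n2nc(C3CC3)nc2n1` gives 3.5 in this assay, and compound 3 `Cc1cc(Nc2ccc(C(F)(F)F)cc2)n2nc(C3CC3)nc2n1` gives 3.3. Compound 2 holds the highest of the three numbers; compound 3 lies nearest to it and within the scatter, while compound 1 lies furthest, beyond the scatter below it. Going by the values given here, the only step among measured compounds that differ in one place is a number 0.20 log units lower from compound 2 to compound 3 (within the scatter), a group of 4 heavy atoms in place of a group of 6 heavy atoms on an aromatic carbon.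

Compound 4 `Cc1cc(Nc2ccc(S(F)(F)(F)(F)F)cc2)n2nc(C(F)(F)F)nc2n1` is not yet measured. It differs from compound 2 by trifluoromethyl in place of cyclopropyl on an aromatic carbon. Among the compounds with values here, no measured step concerns cyclopropyl against trifluoromethyl, so the step from compound 2 to compound 3 is the only guide, and it stayed within the scatter. A small step, if any, is therefore expected, and compound 4 is estimated at 3.4 in this assay, with a range from 3 to 3.8. The expected step is a number 0.10 log units lower from compound 2 to compound 4 (within the scatter).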

Compound 4, distribution coefficient: 3.7
Beside the measured number, compound 4's estimate is 0.30 log units below it; measured number inside the range.
By their numbers in this assay, from the lowest: compound 1; then compounds 3, 2 and 4 (each within the scatter of the next, the first and the last beyond it).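

In this assay the exchange of cyclopropyl for trifluoromethyl on the aromatic carbon between two ring nitrogen atoms gives a number 0.20 log units higher from compound 2 to compound 4 (within the scatter) and is the first step shown at this position of the shared core. Going by these compounds alone, the only earlier step, a number 0.20 log units lower from compound 2 to compound 3 (within the scatter), lay at a different place, so this result adds that the read-out does not separate these two groups at this position, at least with everything else held as in compound 2. No measurement offered here accounts for this result.

On these data alone, it remains open whether the same exchange would give a similarly small step with the group carried by compound 3 elsewhere on the core. As far as these compounds go, how an amine, a carboxylic acid or a longer alkyl chain on this aromatic carbon would read also remains open.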